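Moving the bromine from 2-bromophenyl to 4-bromophenyl

The source may report more compounds than this note shows. Statements on the series, on what has been measured and on what is new or still open speak of the compounds shown alone.

Three compounds sharing one core have numbers in a functional assay on HL-60 cells (Homo sapiens) for antiproliferative activity, with a stated time of 72 h; a lower number here means a stronger inhibitor, a higher number a weaker inhibitor. Compound 1 (`OC[C@H]1O[C@@H](n2cnc3c(NCc4cccc(F)c4)ncnc32)[C@H](O)[C@@H]1O`) gives 920 nM, compound 2 (`OC[C@H]1O[C@@H](n2cnc3c(NCc4ccccc4Cl)ncnc32)[C@H](O)[C@@H]1O`) gives 1600 nM, and compound 3 (`OC[C@H]1O[C@@H](n2cnc3c(NCc4ccccc4Br)ncnc32)[C@H](O)[C@@H]1O`) gives 6600 nM, the highest of the three and so the weakest inhibitor here.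

Compound 4 (`OC[C@H]1O[C@@H](n2cnc3c(NCc4ccc(Br)cc4)ncnc32)[C@H](O)[C@@H]1O`) has 4-bromophenyl in place of 2-bromophenyl on a saturated chain carbon bound to a nitrogen on an aromatic ring. For the measured compounds named here, no measured step moves a bromine alone, so the evidence is indirect. The closest guide is a 7.2-fold higher number from compound 1 to compound 3 (0.86 log units; beyond the scatter), where 2-bromophenyl replaces 3-fluorophenyl. Swapping chloro for bromo gave a 4.1-fold higher number from compound 2 to compound 3 (0.62 log units; beyond the scatter), whereas a 1.7-fold higher number from compound 1 to compound 2 (0.24 log units; within the scatter) stayed within the scatter. Compound 3 thus sits above both neighbours, and removing its 2-bromophenyl may recover part of that gap, though probably not all of it.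

The expected change in this assay is a 2.2-fold lower number from compound 3 to compound 4 (0.34 log units; beyond the scatter), a modest drop in the number. The estimate for compound 4 is 3000 nM, with an expected range of 900 nM to 10000 nM.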

Compound 4, half-maximal inhibitory concentration: 47400 nM
Estimate against measurement, compound 4: 16-fold (1.20 log units) below, and the stated range ends below it.
By their numbers in this assay, from the lowest: compounds 1 and 2 (each within the scatter of the next); then compound 3; then compound 4.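

Compound 3 and compound 4 have the same atoms, yet in this assay 4-bromophenyl in place of 2-bromophenyl gives a 7.2-fold higher number from compound 3 to compound 4 (0.86 log units; beyond the scatter) on its own, so this carbon's substituent is sensitive to where the bromine sits and not only to which halogen is present. The gaps to the other two compounds are larger still, with a 30-fold higher number from compound 2 to compound 4 (1.47 log units; beyond the scatter) and a 52-fold higher number from compound 1 to compound 4 (1.71 log units; beyond the scatter) as well, which leaves compound 4 the weakest inhibitor of the four. Nothing shown here explains why moving one bromine matters this much.

Still open, on these data alone, is whether the drop belongs to bromine itself or would also follow a chloro or methyl group in the place bromo holds in 4-bromophenyl. A plain phenyl group would show whether any halogen helps at all.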